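The source may hold more compounds than are shown below. What is called first, only, known or untested is meant among the compounds shown, and "the series" means these compounds.

In a functional assay on HepG2 cells (Homo sapiens) for cytotoxicity, read by MTT assay, with a stated time of 48 h (a higher number here means a weaker inhibitor, a lower number a stronger inhibitor), compound 3 (`COc1ccc(/C=C/C(=O)/C=C/c2nc3ccccc3n2C)cc1O`) gives 2900 nM, level with compound 1 (`COc1cc(/C=C/C(=O)/C=C/c2nc3ccccc3n2C)ccc1O`) at 2900 nM. Together these two hold the lowest of the three numbers, while compound 2 (`COc1cc(/C=C/C(=O)/C=C/c2nc3c(C)c(C)ccc3n2C)ccc1O`) stands higher at 8500 nM. Compound 4 (`COc1ccc(/C=C/C(=O)/C=C/c2nc3cc(O)ccc3n2C)cc1O`) takes compound 3 and puts hydroxy in place of hydrogen on an aromatic carbon of a six-membered aromatic ring of carbon only, part of a fused or bridged system of two rings: hydroxy in place of hydrogen on an aromatic carbon. Among the compounds with values here, no measured compound carries a hydroxy on that ring, so the data offer no direct guide. The estimated step of no change at the digits printed from compound 3 to compound 4 (within the scatter) is expected to stay within the scatter, with no direction favoured. For compound 4 the estimated value is 2900 nM, with an expected range from 1000 nM to 8000 nM.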

Compound 4, half-maximal inhibitory concentration: 3700 nM
Beside the measured number, compound 4's estimate is 1.3-fold (0.11 log units) below it; the measured number falls inside the stated range.
By their numbers in this assay, from the lowest: compounds 1, 3 and 4 (each within the scatter of the next); then compound 2.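

In this assay, hydroxy in place of hydrogen on an aromatic carbon of the fused ring system gives a 1.3-fold higher number from compound 3 to compound 4 (0.11 log units; within the scatter). Within the data shown here, this position, meta to a fused ring and para to a fused ring, therefore takes a hydroxy with no change beyond the scatter, something the earlier compounds could not show. Nothing measured here explains this result.

From the compounds shown here alone, whether an amine or a carboxylic acid at this carbon would leave the number equally unmoved remains open. So does whether a hydroxy on another carbon of this ring would do the same.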